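The compounds below may be only part of what the source reports. "The series", "measured", "known", "first", "only" and "open" are said of these compounds alone.

In a functional assay on A-375 cells (Homo sapiens) for antiproliferative activity, read by CCK-8 assay, with a stated time of 72 h, tested at 8 uM (a lower number here means a weaker effect, a higher number a stronger effect of the compound at the concentration tested), compound 1 `Nc1ccccc1NC(=O)c1ccc(CSC(=S)N2CCN(c3cccnc3)CC2)cc1` gives 88.8%. Going by the values given here, compound 2 `COc1ccc(N2CCN(C(=S)SCc3ccc(C(=O)Nc4ccccc4N)cc3)CC2)cc1` differs from it in one place, and in this assay compound 2 gives 35.9%, the lowest of the two numbers measured so far; the step of a number 52.9 percentage points lower from compound 1 to compound 2 (beyond the scatter) shows how much that single change cost. Compound 3 `Nc1ccccc1NC(=O)c1ccc(CSC(=S)N2CCN(c3ccc(F)cc3)CC2)cc1` has not yet been measured. It differs from compound 2 as follows: fluoro in place of methoxy on an aromatic carbon, on an aromatic carbon of a six-membered aromatic ring of carbon only, para to a large group. Among the compounds with values here, the only measured step, from compound 1 to compound 2, exchanged the whole group on the ring nitrogen, pyridin-3-yl for 4-methoxyphenyl, and was large; it shows that this part of the molecule matters, but it does not compare two substituents on the same phenyl with each other, so it gives only loose guidance here. A change from methoxy to fluoro at that spot is expected to move the number somewhat, most likely upward, by about a number 9.1 percentage points higher from compound 2 to compound 3 (within the scatter). Compound 3 is therefore estimated at 45%, with a range from 20% to 72%.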

Compound 3, a percentage reported as inhibition, at one concentration (the size of the read-out at that concentration, not a potency): 76.3%
Compound 3: the middle estimate sits 31.3 percentage points below what was measured, outside the stated range (above it).
By their numbers in this assay, from the lowest: compound 2; then compound 3; then compound 1.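

In this assay the group on the aromatic carbon para to a large group turns out to matter by itself: with everything else in the molecule kept the same, fluoro in place of methoxy gives a number 40.4 percentage points higher from compound 2 to compound 3 (beyond the scatter) and this single exchange is large. The earlier step replaced the whole group on the ring nitrogen and so could not separate the ring from its substituent, but 4-fluorophenyl in place of pyridin-3-yl gives a number 12.5 percentage points lower from compound 1 to compound 3 (beyond the scatter) and that step is only modest, which shows that a phenyl ring in this spot does not by itself bring the number down to that of compound 2.

With only methoxy and fluoro at this carbon, the compounds shown leave open how a chloro, methyl or amino group, or a phenyl ring with no substituent at all, would compare. They also leave open whether fluoro gives a similar result elsewhere on the ring, and nothing measured on these compounds explains why so small an exchange moves the number this far.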